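The source may hold more compounds than are shown below. What is called first, only, known or untested is meant among the compounds shown, and "the series" means these compounds.

The measured compounds:

Compound 1, `Cn1c(=O)ccn([C@@H]2O[C@H](COP(=O)(O)OP(=O)(O)O)[C@@H](O)[C@H]2O)c1=O`, gives 3300 nM in an in vitro functional assay on 1321-N1 cells for agonist activity at P2Y purinoceptor 6 (Homo sapiens); on this read-out higher numbers stand for an effect only at larger amounts of compound and lower numbers for an effect already at smaller amounts.
Compound 2, `O=C(O)CSc1ccn([C@@H]2O[C@H](COP(=O)(O)OP(=O)(O)O)[C@@H](O)[C@H]2O)c(=O)n1`, gives 1700 nM in this assay.
Compound 3, `N[C@@H]1[C@H](O)[C@@H](COP(=O)(O)OP(=O)(O)O)O[C@H]1n1ccc(=O)[nH]c1=O`, gives 3900 nM in this assay.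

Compound 2 has the lowest of the three numbers. Its gap to compound 1 lies within the usual scatter of repeated measurements, so the two cannot be told apart; its gap to compound 3 lies beyond the scatter. Compound 4, `O=C(O)CCCSc1ccn([C@@H]2O[C@H](COP(=O)(O)OP(=O)(O)O)[C@@H](O)[C@H]2O)c(=O)n1`, differs from compound 2 in one place: 2-carboxyethyl in place of carboxy on a saturated chain carbon bound to a sulfur. The rest of the molecule, the shared core with its sugar and diphosphate, is unchanged. Among the measured compounds shown here, no measured pair shows what lengthening this chain does; the three measured compounds differ from one another in other places, so the direction of the step has to be guessed. The expectation is a small step, if any, not clearly beyond the scatter, with a slight lean towards a higher number. Compound 4 is therefore expected to give about 2500 nM, with a range from 800 nM to 8000 nM. The expected step from compound 2 to compound 4 is a 1.5-fold higher number from compound 2 to compound 4 (0.17 log units; within the scatter).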

Compound 4, half-maximal effective concentration: 8800 nM
Estimate against measurement, compound 4: 3.5-fold (0.55 log units) below; the measured number lies above the stated range.
By their numbers in this assay, from the lowest: compounds 2, 1 and 3 (each within the scatter of the next, the first and the last beyond it); then compound 4.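

This position is not indifferent to chain length: in this assay, replacing (carboxymethyl)sulfanyl with (3-carboxypropyl)sulfanyl gives a 5.2-fold higher number from compound 2 to compound 4 (0.71 log units; beyond the scatter) and lies beyond the scatter. The carboxy group remains and the shared core is unchanged, so the difference lies in the chain that links them, and the higher number means that more of compound 4 is needed for the same effect. The data shown offer no measurement that explains this loss.

A single pair cannot show whether a longer chain would raise the number further, or whether (2-carboxyethyl)sulfanyl would fall between these two compounds. It also leaves open whether the carboxylic acid itself matters, which an amine or a plain methyl in its place could test.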